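Swapping a pyridine for a thiophene at the side-chain

A few compounds are considered here, and "the series" means these few. Any claim that something is new, unique, unknown or untested is made for them only; others in the source may bear on it.

Measured so far:
- Compound 1 `Nc1nc(NCc2ccncc2)nc2sc(-c3ccco3)nc12` gives 47 nM in an assay on CHO cells for displacement of a labelled ligand from adenosine receptor A1 (Homo sapiens), read by scintillation counting, with a stated time of 90 min; a higher number here means a weaker inhibitor, a lower number a stronger inhibitor
- Compound 2 `Nc1nc(NCc2cccnc2)nc2sc(-c3ccco3)nc12` gives 7.12 nM in this assay

Both compounds share a core and differ only in the aromatic ring hanging from the methylene attached to the ring nitrogen. Within the data shown here, the one measured step, a 6.6-fold lower number from compound 1 to compound 2 (0.82 log units; beyond the scatter), shows that moving the nitrogen within that six-membered ring changes the number noticeably. Among the measured compounds shown here, compound 2 therefore stands with the lowest of the two numbers, compound 1 being the only neighbour.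

Compound 3 `Nc1nc(NCc2ccsc2)nc2sc(-c3ccco3)nc12` is the next step from compound 2. The change is thiophen-3-yl in place of pyridin-3-yl on a saturated chain carbon bound to a nitrogen on an aromatic ring. This is not the same kind of change as the one already measured: the earlier step kept the six-membered ring and only shifted the hetero atom, whereas here the ring size and the hetero atom itself both change. The measured step bears on the expectation only loosely, in that it shows this position is sensitive. With no closer comparison, the expected step is a 1.7-fold higher number from compound 2 to compound 3 (0.23 log units; within the scatter). Compound 3 is therefore estimated at 12 nM, with a range from 3 nM to 45 nM.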

Compound 3, inhibition constant: 8.12 nM
Compound 3: the middle estimate sits 1.5-fold (0.17 log units) above what was measured, within the range that was stated.
By their numbers in this assay, from the lowest: compounds 2 and 3 (each within the scatter of the next); then compound 1.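

In this assay, the step to the thiophen-3-yl ring, a 1.1-fold higher number from compound 2 to compound 3 (0.06 log units; within the scatter), shows that this position can take a five-membered ring with a sulfur as readily as the six-membered pyridin-3-yl ring with its nitrogen, so neither the ring size nor the ring nitrogen of compound 2 is needed to keep the number this low. The other step, a 5.8-fold lower number from compound 1 to compound 3 (0.76 log units; beyond the scatter), extends what the two pyridines showed: among the three groups on this chain carbon, the pyridin-4-yl of compound 1 is the one that stands apart, while a ring with no nitrogen at all matches the pyridin-3-yl ring within the scatter. Nothing available here explains why these rings compare as they do.

The compounds shown leave open whether this tolerance extends to a plain phenyl ring, to the isomeric thiophen-2-yl ring, or to a furan ring at this place. They also leave open how a longer chain between the aromatic ring and the nitrogen would read in this assay.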